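This account rests on a few compounds, and the source may have more. Where it says the series, first, only, none or still open, it means among the compounds named here.

This account follows a short series built on a shared core, with compound 1 `O=C(Nc1ccc(O)cc1)C1CCc2ccccc2N1` and compound 2 `O=C(Nc1cc(C(F)(F)F)cc(C(F)(F)F)c1)C1CCc2ccccc2N1` tested in a functional assay on MDA-MB-231 cells (Homo sapiens) for cytotoxicity, read by sulforhodamine B assay, with a stated time of 72 h; a lower number here means a stronger inhibitor of growth, a higher number a weaker inhibitor of growth. Compound 1 gives only a limit of the assay in this assay, > 100000 nM. In this assay compound 2 gives 8270 nM. Compound 1 therefore stands at the limit of > 100000 nM in this assay, at which 1 of the 2 values shown sits, so no number of its own is known for it. Compound 3 `O=C(Nc1ccccc1)C1CCc2ccccc2N1` is the unmeasured partner of compound 1, and it differs from it by hydrogen in place of hydroxy on an aromatic carbon. Among the measured compounds shown here, no measured step links compound 1 to compound 3, so the size of the step in this assay is open; with compound 1 sitting at a limit, a move toward a lower number beyond the scatter seems more likely than a move upward, though the outcome could again be a limit rather than a number. Compound 3 is expected to give about 60000 nM in this assay, with a range from 15000 nM to 300000 nM. The expected step is an at least 1.6-fold lower number from compound 1 to compound 3 (0.22 log units; that floor lies within the scatter).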

Compound 3, concentration for 50% growth inhibition: 108000 nM
The estimate for compound 3 lay 1.8-fold (0.26 log units) below the measured number; the measured number falls inside the stated range.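

No step can be read from compound 1 to compound 3 in this assay, where hydrogen stands in place of hydroxy on an aromatic carbon, and the one limit involved belongs to compound 1: the limit of > 100000 nM in this assay, at which 1 of the 3 values shown sits.

The compounds shown leave open whether this exchange changes growth inhibition at all, and if it does, by how much.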